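Working notes: 3-chlorophenyl in place of 4-chlorophenyl

This account rests on a few compounds, and the source may have more. Where it says the series, first, only, none or still open, it means among the compounds named here.

compound 1 (`CC(C)=CCn1cnc2c(Nc3cccc(Cl)c3)nc(N[C@H]3CC[C@H](N)CC3)nc21`) : 80 nM
compound 2 (`CCCCn1cnc2c(Nc3ccc(Cl)cc3)nc(N[C@H]3CC[C@H](N)CC3)nc21`) : 50 nM

In a functional assay on EOL1 cells (Homo sapiens) for inhibition, read by fluorescence, with a stated time of 72 h (a higher number here means a weaker inhibitor of growth, a lower number a stronger inhibitor of growth), compound 2 at 50 nM lies within the scatter of compound 1 at 80 nM and so holds no rank. Compound 3 (`CCCCn1cnc2c(Nc3cccc(Cl)c3)nc(N[C@H]3CC[C@H](N)CC3)nc21`) carries 3-chlorophenyl in place of 4-chlorophenyl on a nitrogen on an aromatic ring. Within the data shown here, no measured pair isolates this change, so no step beyond the scatter is expected in this assay in either direction. The expected step is a 1.1-fold higher number from compound 2 to compound 3 (0.04 log units; within the scatter) and stays within the scatter. Compound 3 is expected at 55 nM with an estimated range of 22 nM to 130 nM as a working guide.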

Compound 3, concentration for 50% growth inhibition: 160 nM
The estimate for compound 3 lay 2.9-fold (0.46 log units) below the measured number; the whole stated range lies below it.
By their numbers in this assay, from the lowest: compounds 2, 1 and 3 (each within the scatter of the next, the first and the last beyond it).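

In this assay, among these compounds, the pair gives the first reading on this position, and a 3.2-fold higher number from compound 2 to compound 3 (0.51 log units; beyond the scatter) marks 3-chlorophenyl in place of 4-chlorophenyl as a modest loss on this nitrogen. With 3-chlorophenyl held, the chain change gives a 2.0-fold higher number from compound 1 to compound 3 (0.30 log units; within the scatter), so propyl in place of 2-methylprop-1-en-1-yl cannot be told apart here. Nothing available accounts for the chlorine step.

Still open, as far as these compounds go, is whether the chlorine step holds with the 2-methylprop-1-en-1-yl chain. Also open, from the compounds shown here alone, is how 2-chlorophenyl, unsubstituted phenyl or 4-methoxyphenyl would read on this nitrogen.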